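A few compounds are considered here, and "the series" means these few. Any claim that something is new, unique, unknown or untested is made for them only; others in the source may bear on it.

Of the compounds shown here, three from one series have so far been tested in an ADME assay on 2209-23 cells (Homo sapiens) for cytotoxicity, read by WST assay and thymidine incorporation; a lower number here means that less compound is tolerated, a higher number that more compound is tolerated. Compound 1 `CC(=O)C1=C(C2=C(O)[C@H](C(C)(C)C)N(Cc3ccc(F)cc3)C2=O)Nc2ccc(NS(C)(=O)=O)cc2S1(=O)=O` gives in this assay only a limit, > 50000 nM. Compound 2 `CC(C)(C)[C@H]1C(O)=C(C2=CS(=O)(=O)c3cc(NS(C)(=O)=O)cc(F)c3N2)C(=O)N1Cc1ccc(F)cc1` likewise returns a limit in this assay, > 50000 nM. Compound 3 `Cc1cc(CN2C(=O)C(C3=CS(=O)(=O)c4cc(NS(C)(=O)=O)ccc4N3)=C(O)[C@@H]2C(C)(C)C)ccc1F` also reaches a limit in this assay, > 50000 nM. Where compound 3 stands is thus known only as a limit, and the two further values shown are limits as well; all three sit at the limit of > 50000 nM in this assay, at which 3 of the 3 values shown sit. No pair among these three differs in a single place, so no measured step can be read from them, and each value shows only that the compound was tolerated up to the limit of the assay.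

Compound 4 `COc1cc(CN2C(=O)C(C3=CS(=O)(=O)c4cc(NS(C)(=O)=O)ccc4N3)=C(O)[C@@H]2C(C)(C)C)ccc1F` differs from compound 3 in one place: methoxy in place of methyl on an aromatic carbon. The exchange is confined to a single group on the 4-fluoro-3-methylbenzyl part, which becomes 4-fluoro-3-methoxybenzyl.

Since compound 3 sits at a limit in this assay, the step from compound 3 to compound 4 is expected to be a number no higher from compound 3 to compound 4 (the limit leaves the size open), that is, none beyond the scatter in either direction. Compound 4 is accordingly estimated at 50000 nM in this assay, within a range of 25000 nM to 200000 nM, and is most likely to be reported again only as a limit.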

Compound 4, half-maximal cytotoxic concentration: > 50000 nM
Compound 4 was reported as a limit; the forecaster's own chance of this, stated with the estimate: 85%; the middle value lies on the limit itself.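

In this assay, compound 3 and compound 4 both stand only as limits, so the exchange of methyl for methoxy gives no readable step: the limit of > 50000 nM in this assay, at which 4 of the 4 values shown sit.

The compounds shown leave open at what concentration any of them becomes cytotoxic to these cells, and whether any change in structure would move that concentration.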